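Hydrogen in place of bromo: compound 2 to compound 4

A few compounds are considered here, and "the series" means these few. Any claim that something is new, unique, unknown or untested is made for them only; others in the source may bear on it.

Three compounds of the shared core have been run in a physicochemical assay for pharmacokinetics (on this read-out higher numbers stand for a longer-lived compound and lower numbers for a shorter-lived compound), so far. Compound 1 `O=C(NCc1ccc(C(F)(F)F)cc1)N1C(=O)c2ccccc2S1(=O)=O` gives > 166 h in this assay, which is a limit of the assay and not a number. Compound 2 `O=C(NCc1ccccc1Br)N1C(=O)c2ccccc2S1(=O)=O` gives > 166 h in this assay, again a limit. Compound 3 `O=C(CCc1ccccc1)N1C(=O)c2ccccc2S1(=O)=O` gives > 166 h in this assay, also a limit. For the measured compounds named here, compound 2 thus stands where every value so far stands, namely at the limit of > 166 h in this assay, at which 3 of the 3 values shown sit; nothing measured places it apart from compound 1 or compound 3, and no step between measured compounds can be read off.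

Compound 4 `O=C(NCc1ccccc1)N1C(=O)c2ccccc2S1(=O)=O` has not yet been measured in this assay. It differs from compound 2 in one place: hydrogen in place of bromo on an aromatic carbon. Going by the values given here, all three values so far are limits, so no measured step tells how the loss of the bromo group acts on the half-life, and no size of step can be derived from the data. The step from compound 2 to compound 4 in this assay is expected to be none beyond the scatter, a step that the limit leaves unreadable from compound 2 to compound 4. Compound 4 is therefore expected to give about 200 h in this assay, with a range from 80 h to 500 h, and it is expected that the assay will most likely again report only a limit.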

Compound 4, half-life: > 166 h
Compound 4: only a limit was reported; the forecaster's own chance of this, stated with the estimate: 85%; the middle value is on the limit's open side.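

In this assay compound 4 gives > 166 h, a limit of the assay and not a number. No step to compound 4 can be read from compound 2 or compound 1, because the values share one limit: the limit of > 166 h in this assay, at which 4 of the 4 values shown sit.

As far as these compounds go, whether bromo or trifluoromethyl in place of hydrogen changes the half-life in this assay remains open.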